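This account rests on a few compounds, and the source may have more. Where it says the series, first, only, none or still open, it means among the compounds named here.

Compound 1, `COc1ccc(-c2nc3ccccc3c(C(=O)N[C@@H](C)c3ccccc3)c2CN2CCC(N3CCCCC3)CC2)cc1` — 5010 nM
Compound 2, `Cc1ccc(-c2nc3ccccc3c(C(=O)N[C@@H](C)c3ccccc3)c2CN2CCC(N3CCCCC3)CC2)cc1` — 1580 nM

For the measured compounds named here, in an assay on HEK293 cells for antagonist activity at transient receptor potential cation channel subfamily V member 4 (Homo sapiens), read by FLIPR and calcium flux, with a stated time of 10 min (a higher number here means a weaker inhibitor, a lower number a stronger inhibitor), compound 2 gives 1580 nM, the lowest of the two numbers measured so far. Going by the values given here, its only neighbour is compound 1, which in this assay gives 5010 nM; the single measured step between them is a 3.2-fold lower number from compound 1 to compound 2 (0.50 log units; beyond the scatter), a modest change that lies beyond the scatter.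

Compound 3, `C[C@H](NC(=O)c1c(CN2CCC(N3CCCCC3)CC2)c(-c2ccc(Cl)cc2)nc2ccccc12)c1ccccc1`, differs from compound 2 in one place: chloro in place of methyl on an aromatic carbon. Among the compounds with values here, the one measured step, the methyl in place of methoxy, touches the same aromatic carbon but exchanges a different pair of groups, so it bears on the new step only in showing that this position tolerates a small substituent without a large swing. Within the data shown here, no measured pair shows what chloro does here. A step of no more than the usual scatter, perhaps a slight lowering, is therefore expected: in this assay compound 3 is estimated at 1200 nM, with a range of 400 nM to 4000 nM. The expected step is a 1.3-fold lower number from compound 2 to compound 3 (0.12 log units; within the scatter).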

Compound 3, half-maximal inhibitory concentration: 320 nM
Compound 3: middle estimate off by 3.8-fold (0.57 log units), on the high side; the whole stated range lies above it.
By their numbers in this assay, from the lowest: compound 3; then compound 2; then compound 1.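

For the compounds shown here, the exchange of methyl for chloro, one heavy atom for one with no hydrogen-bond donor or acceptor on either side, gives in this assay a 4.9-fold lower number from compound 2 to compound 3 (0.69 log units; beyond the scatter), so this aromatic carbon responds clearly to a swap of a single atom, which the earlier compounds, differing only by methyl and methoxy, could not show. Measured against the methoxy group, the same position gives a 16-fold lower number from compound 1 to compound 3 (1.19 log units; beyond the scatter), a much wider span than the first pair suggested, and the three compounds now fall in the order chloro, methyl, methoxy from the lowest number to the highest, with compound 3 the lowest of them. Nothing available accounts for this order, and the three values alone cannot tie it to any property of the groups.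

The compounds shown leave open whether fluoro, bromo, trifluoromethyl or nitrile at this carbon would give a number lower still than chloro, and how an amine or a carboxylic acid would fare there. They also leave open whether the order of these three groups holds once another part of the shared core is changed.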